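Swapping the pyrimidine attachment point on a longer chain

The compounds below may be only part of what the source reports. "The series", "measured", "known", "first", "only" and "open" are said of these compounds alone.

Compound 1, `Clc1ccc2c(NCCNc3nccc(Cl)n3)ccnc2c1`, gives 2850 nM in a physicochemical assay for solubility, read by HPLC, measured as octanol-water partition, at pH 7.4; a lower number here means a less soluble compound, a higher number a more soluble compound.
Compound 2, `Clc1ccc2c(NCCNc3ccnc(Cl)n3)ccnc2c1`, gives 2090 nM in this assay.
Compound 3, `Clc1ccc2c(NCCCCCCCCNc3nccc(Cl)n3)ccnc2c1`, gives 2910 nM in this assay.

Compound 4, `Clc1ccc2c(NCCCCCCCCNc3ccnc(Cl)n3)ccnc2c1`, has not yet been measured. It is related to compound 3 by the change (2-chloropyrimidin-4-yl in place of 4-chloropyrimidin-2-yl on an amine nitrogen). The same change, (2-chloropyrimidin-4-yl in place of 4-chloropyrimidin-2-yl on an amine nitrogen), joins compound 1 to compound 2, where it produced the step of a 1.4-fold lower number from compound 1 to compound 2 (0.13 log units; within the scatter). In both pairs the place is described in the same words, so this is the same change made on two different cores; how the core of compound 3 differs from the core of compound 1 is not broken down here. The values of compound 3, compound 1 and compound 2 all lie within the usual scatter of one another, so none of them can be called more or less soluble than the others.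

For compound 4 the expected step is a 1.4-fold lower number from compound 3 to compound 4 (0.14 log units; within the scatter), resting on the step seen before, a 1.4-fold lower number from compound 1 to compound 2 (0.13 log units; within the scatter). The estimate for compound 4 in this assay is 2100 nM, with a likely range from 1200 nM to 3700 nM.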

Compound 4, solubility: 2410 nM
Beside the measured number, compound 4's estimate is 1.1-fold (0.06 log units) below it; the measured number falls inside the stated range.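

In this assay, putting 2-chloropyrimidin-4-yl in place of 4-chloropyrimidin-2-yl on an amine nitrogen gives a 1.2-fold lower number from compound 3 to compound 4 (0.08 log units; within the scatter) on the core of compound 3, while on the core of compound 1 the same change gives a 1.4-fold lower number from compound 1 to compound 2 (0.13 log units; within the scatter) as the earlier step. Both steps lie within the scatter, so neither pair separates the two attachments, and on these two cores the result carries over only in that sense: it does not show a real difference of a fixed size, and two pairs cannot show that the same would hold on every core in the series. Nothing shown here bears on why the two pairs look alike.

As far as these compounds go, it remains open whether the two attachments would also stay this close with a longer chain, or with an amine or a carboxylic acid on the chain. The same question stands for a methoxy group or a fluorine in place of the chlorine on the pyrimidine.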